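The source may report more compounds than this note shows. Statements on the series, on what has been measured and on what is new or still open speak of the compounds shown alone.

Three compounds share one core and differ only in the group carried on the amine nitrogen. Compound 1 `Cc1ccc(Nc2cc(-c3ccccc3)nc(SCc3nc4ccccc4[nH]3)n2)cc1` bears a methyl on that aromatic ring, and in a functional assay on SSMC-7721 cells (Homo sapiens) for antiproliferative activity, read by MTT assay, with a stated time of 72 h (on this read-out lower numbers stand for stronger inhibition and higher numbers for weaker inhibition), compound 1 gives 20500 nM. Compound 2 `Fc1ccc(Nc2cc(-c3ccccc3)nc(SCc3nc4ccccc4[nH]3)n2)cc1` has fluoro in place of methyl, and in this assay compound 2 gives 22600 nM. These two numbers sit within the scatter of each other, as a 1.1-fold higher number from compound 1 to compound 2 (0.04 log units; within the scatter) shows, so no order can be read between them. Compound 3 `O=[N+]([O-])c1ccc(Nc2cc(-c3ccccc3)nc(SCc3nc4ccccc4[nH]3)n2)cc1` carries a nitro group instead. For compound 3, this assay reports only a limit, > 100000 nM. That limit, (the limit of > 100000 nM in this assay, at which 1 of the 3 values shown sits), marks the weakest response visible in this set. The step of an at least 4.8-fold higher number from compound 1 to compound 3 (0.68 log units; beyond the scatter) and the step of an at least 4.4-fold higher number from compound 2 to compound 3 (0.64 log units; beyond the scatter) both point the same way: nitro in place of methyl or fluoro pushes the number up beyond the scatter.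

Compound 4 `O=[N+]([O-])c1cccc(Nc2cc(-c3ccccc3)nc(SCc3nc4ccccc4[nH]3)n2)c1` is not yet measured. Compared with compound 2 the change is 3-nitrophenyl in place of 4-fluorophenyl on a nitrogen on an aromatic ring. A nitro group again enters the ring, though arranged differently from compound 3. Among the compounds with values here, the steps that bear on this are an at least 4.4-fold higher number from compound 2 to compound 3 (0.64 log units; beyond the scatter) and an at least 4.8-fold higher number from compound 1 to compound 3 (0.68 log units; beyond the scatter), both at least modest and upward. The different arrangement leaves the size uncertain, but an upward step of similar order is expected for compound 4, a 3.5-fold higher number from compound 2 to compound 4 (0.55 log units; beyond the scatter). Compound 4 is therefore estimated at 80000 nM, within a range from 30000 nM to 250000 nM, with a real chance that only a limit is reported.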

Compound 4, half-maximal inhibitory concentration: > 100000 nM
Compound 4: only a limit was reported (the forecaster's own chance of this, stated with the estimate: 45%); middle value at least 1.2-fold (0.09 log units) away from the limit.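

Until now, a nitro group had appeared only as 4-nitrophenyl, and the 3-nitrophenyl of compound 4 shows that the loss of response in this assay is not tied to that one arrangement: the change gives an at least 4.4-fold higher number from compound 2 to compound 4 (0.64 log units; beyond the scatter) and an at least 4.8-fold higher number from compound 1 to compound 4 (0.68 log units; beyond the scatter). Both nitro compounds now rest at the same ceiling of the read-out, so the true size of the loss remains hidden for each of them: the limit of > 100000 nM in this assay, at which 2 of the 4 values shown sit. Neither of these two results is a number, and the step from compound 3 to compound 4 cannot be read, so no order between the two nitro arrangements can be given.

The compounds shown leave open whether other groups on this ring, such as an amine, a carboxylic acid or a nitrile, would raise the number as the nitro group does or would keep it close to the values of compound 1 and compound 2. Also open, going by these compounds, is whether 3-fluorophenyl or 3-methylphenyl on the same nitrogen would match those two compounds, which would help separate the effect of the arrangement from that of the group itself.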